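This account rests on a few compounds, and the source may have more. Where it says the series, first, only, none or still open, it means among the compounds named here.

Measured so far in a functional assay on COLO 205 cells (Homo sapiens) for inhibition, read by sulforhodamine B assay, with a stated time of 48 h, tested at 10 uM; a lower number here means a stronger effect, a higher number a weaker effect of the compound at the concentration tested:
Compound 1 `O=C(Nc1cccc(-n2cc(-c3ccncc3)c(-c3cc(O)cc(Cl)c3)n2)c1)Nc1ccc(Cl)c(Cl)c1` gives 22.4% in this assay.
Compound 2 `COc1cc(Cl)cc(-c2nn(-c3cccc(NC(=O)Nc4ccc(Cl)c(Cl)c4)c3)cc2-c2ccncc2)c1` gives -70.3% in this assay.
Compound 3 `O=C(Nc1cccc(-n2cc(-c3ccncc3)c(-c3cc(O)cc(Cl)c3)n2)c1)c1cc(C(F)(F)F)cc(C(F)(F)F)c1` gives 38.7% in this assay.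

Compound 2 differs from compound 1 by one change, (methyl in place of hydrogen on an oxygen on an aromatic ring), and this step made a number 92.7 percentage points lower from compound 1 to compound 2 (beyond the scatter). Compound 3 carries a different core; how its core differs from that of compound 1 is not broken down here. Its value in this assay stands highest of the three measured numbers.

Compound 4 `COc1cc(Cl)cc(-c2nn(-c3cccc(NC(=O)c4cc(C(F)(F)F)cc(C(F)(F)F)c4)c3)cc2-c2ccncc2)c1` is the not yet measured partner of compound 3, differing by the same change, (methyl in place of hydrogen on an oxygen on an aromatic ring). The step is expected to be a number 78.7 percentage points lower from compound 3 to compound 4 (beyond the scatter), a large fall, because the same change made a number 92.7 percentage points lower from compound 1 to compound 2 (beyond the scatter). Resting on that single earlier step only, compound 4 is estimated at -40%, between -95% and 20%.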

Compound 4, a percentage reported as activity, at one concentration (the size of the read-out at that concentration, not a potency): 88.7%
Compound 4: middle estimate off by 128.7 percentage points, on the low side, outside the stated range (above it).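

Replacing hydroxy with methoxy on the 3-chloro-5-hydroxyphenyl group gave a number 50 percentage points higher from compound 3 to compound 4 (beyond the scatter) in this assay, so on this core the change weakened the effect. The change therefore did not carry from one core to the other, and its direction reversed: the same change on two cores in this assay, a number 92.7 percentage points lower (beyond the scatter) from compound 1 to compound 2 and a number 50 percentage points higher (beyond the scatter) from compound 3 to compound 4, 142.7 percentage points apart, beyond the scatter of two such steps

The two pairs show that the result of this change depends on the rest of the molecule, but they do not show which difference between the cores reverses it, and they give no rule for a third core. The compounds shown leave open how an ethyl group on the same oxygen, or an amine in place of the hydroxy, would behave on either core.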